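Chain shortening on the amine-bearing analogue of the core

This account rests on a few compounds, and the source may have more. Where it says the series, first, only, none or still open, it means among the compounds named here.

Working notes on a small set sharing the core of compound 1, `Nc1cccc(-c2cn3nc(-c4cccs4)sc3n2)c1`, tested in a functional assay on CCRF-CEM cells (Homo sapiens) for inhibition, read by cell counting, with a stated time of 3 days; a higher number here means a weaker inhibitor, a lower number a stronger inhibitor. Compound 1 gives only the assay limit there, > 250000 nM, which is a limit and not a number. Compound 2, `C=C(Br)C(=O)Nc1cccc(-c2cn3nc(Cc4ccccc4)sc3n2)c1`, gives 4200 nM in this assay. Going by the values given here, compound 3, `Nc1cccc(-c2cn3nc(CCc4ccccc4)sc3n2)c1`, gives 30000 nM, the higher of the two measured numbers, with compound 2 the lower of the pair; the two differ in the substituent on the core and in the group on the aniline nitrogen, so no single step connects them.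

Compound 4, `Nc1cccc(-c2cn3nc(Cc4ccccc4)sc3n2)c1`, is not yet measured. It differs from compound 3 by phenyl in place of benzyl on a saturated chain carbon bound to an aromatic carbon, while the free amine of compound 3 is kept. Among the compounds with values here, no measured pair shows this change alone. With the amine retained, compound 4 is expected to stay in the weak range of compound 3 in this assay, and the step from compound 3 to compound 4 is estimated as no change at the digits printed from compound 3 to compound 4 (within the scatter), not beyond the scatter. Compound 4 is therefore estimated at 30000 nM, within 8000 nM to 150000 nM.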

Compound 4, half-maximal inhibitory concentration: 37000 nM
Beside the measured number, compound 4's estimate is 1.2-fold (0.09 log units) below it; measured number inside the range.
By their numbers in this assay, from the lowest: compound 2; then compounds 3 and 4 (each within the scatter of the next). At a limit, above all of these: compound 1.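

Going by these compounds alone, with the free amine kept, phenyl in place of benzyl on a saturated chain carbon bound to an aromatic carbon gives a 1.2-fold higher number from compound 3 to compound 4 (0.09 log units; within the scatter) in this assay, so this shortening of the chain, seen here on its own for the first time, leaves no readable mark on the result. The group on the aniline nitrogen now has a single-place reading: hydrogen in place of (1-bromoethenyl)carbonyl on a nitrogen on an aromatic ring gives an 8.8-fold higher number from compound 2 to compound 4 (0.94 log units; beyond the scatter), a step that lies beyond the scatter, unlike the chain change. At the other place on the core, benzyl in place of thiophen-2-yl on an aromatic carbon gives an at least 6.7-fold lower number from compound 1 to compound 4 (0.82 log units; beyond the scatter), a step whose starting value is a limit and not a number, so its true size stays unknown: the limit of > 250000 nM in this assay, at which 1 of the 4 values shown sits.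

Whether the chain stays this flat further out remains open, since the compounds shown stop short of a longer chain such as 3-phenylpropyl and of a small group such as methyl at this place. As far as these compounds go, it is also open how much of the nitrogen step belongs to the bromine, which a plain acetyl or acryloyl group on the same nitrogen would separate.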